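This account rests on a few compounds, and the source may have more. Where it says the series, first, only, none or still open, it means among the compounds named here.

Compound 1 `CN1CCC(n2cc(S(=O)(=O)c3ccc(Cl)cc3)c3cccnc32)C1` gives 4.2 nM in an assay on HeLa cells for displacement of a labelled ligand from 5-hydroxytryptamine receptor 6 (Homo sapiens); a higher number here means a weaker inhibitor, a lower number a stronger inhibitor.
Compound 2 `O=S(=O)(c1ccc(Cl)cc1)c1cn(C2CCCNC2)c2ncccc12` gives 7.6 nM in this assay.
Compound 3 `CCN1CCCC(n2cc(S(=O)(=O)c3ccc(Cl)cc3)c3cccnc32)C1` gives 33.5 nM in this assay.

Compound 2 stands second highest of the three numbers; its nearest neighbour is compound 1, with a 1.8-fold higher number from compound 1 to compound 2 (0.26 log units; within the scatter), and its furthest is compound 3, with a 4.4-fold higher number from compound 2 to compound 3 (0.64 log units; beyond the scatter). Compound 4 `O=S(=O)(c1cc(Cl)cc(Cl)c1)c1cn(C2CCCNC2)c2ncccc12` is not yet measured. It differs from compound 2 in one place: 3,5-dichlorophenyl in place of 4-chlorophenyl on a sulfonyl sulfur. Among the measured compounds shown here, none of the measured steps touches this part of the molecule; an 8.0-fold higher number from compound 1 to compound 3 (0.90 log units; beyond the scatter) and the two steps already named all alter the ring on the aromatic nitrogen, not the group on the sulfonyl sulfur. The data therefore give no direct guide, and no step beyond the scatter is expected in this assay, though an estimated 1.6-fold higher number from compound 2 to compound 4 (0.20 log units; within the scatter) is allowed for. Compound 4 is expected to give 12 nM, between 3 nM and 50 nM.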

Compound 4, inhibition constant: 6.1 nM
Compound 4: middle estimate off by 2.0-fold (0.29 log units), on the high side, within the range that was stated.
By their numbers in this assay, from the lowest: compounds 1, 4 and 2 (each within the scatter of the next); then compound 3.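

In this assay the change from 4-chlorophenyl to 3,5-dichlorophenyl gives a 1.2-fold lower number from compound 2 to compound 4 (0.10 log units; within the scatter) and is the first step shown on the sulfonyl sulfur, since the earlier steps all altered the ring on the aromatic nitrogen. For this one pair, a second chlorine on the phenyl ring leaves the number within the scatter. No measurement here offers an explanation for this result.

Going by these compounds, how an unsubstituted phenyl or a methoxyphenyl on the sulfonyl sulfur would compare remains open. So does whether 3,5-dichlorophenyl behaves the same with 1-methylpyrrolidin-3-yl on the aromatic nitrogen.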